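This account rests on a few compounds, and the source may have more. Where it says the series, first, only, none or still open, it means among the compounds named here.

The three measured compounds share one core in which an enaminone bridges an aniline and a substituted pyrazole. Compound 1 `COc1ccc(N/C=C\C(=O)c2cn(-c3ccccc3)nc2-c2ccccc2)cc1` carries an unsubstituted phenyl on the core and a methoxy on the aniline. In an ADME assay on HaCaT cells (Homo sapiens) for antiproliferative activity, read by MTT assay, with a stated time of 48 h (on this read-out higher numbers stand for weaker inhibition and lower numbers for stronger inhibition), compound 1 gives > 50000 nM, which is a limit of the assay and not a number. Compound 2 `COc1ccc(-c2nn(-c3ccccc3)cc2C(=O)/C=C\Nc2ccc(F)cc2)cc1` carries a methoxyphenyl on the core and a fluoro on the aniline; in this assay compound 2 gives 8910 nM. Compound 3 `COc1ccc(-c2nn(-c3ccccc3)cc2C(=O)/C=C\Nc2ccc(C(F)(F)F)cc2)cc1` has a trifluoromethyl where compound 2 has the fluoro. In this assay compound 3 gives > 50000 nM, again a limit rather than a number. Among the measured compounds shown here, the only measured step, an at least 5.6-fold higher number from compound 2 to compound 3 (0.74 log units; beyond the scatter), thus ends at the limit of > 50000 nM in this assay, at which 2 of the 3 values shown sit, and compound 3 stands there, with nothing more precise to read.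

Compound 4 `COc1ccc(N/C=C\C(=O)c2cn(-c3ccccc3)nc2-c2ccc(OC)cc2)cc1` differs from compound 3 by methoxy in place of trifluoromethyl on an aromatic carbon. The measured step from compound 2 to compound 3 touches the same aromatic carbon but does not cover a methoxy there, and compound 1, which lacks both groups at that carbon, also sits at the limit. Compound 4 is therefore expected to stay near the limit, so the step of an at least 1.1-fold lower number from compound 3 to compound 4 (0.04 log units; that floor lies within the scatter) in this assay is expected to lie within the scatter. For compound 4 the estimate in this assay is 45000 nM, in a range from 12000 nM to 120000 nM.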

Compound 4, half-maximal inhibitory concentration: > 50000 nM
Compound 4: only a limit was reported; the forecaster's own chance of this, stated with the estimate: 60%; at least 1.1-fold (0.04 log units) between middle value and limit.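

In this assay, methoxy in place of fluoro on the aniline gives an at least 5.6-fold higher number from compound 2 to compound 4 (0.74 log units; beyond the scatter), so methoxy joins trifluoromethyl as a second group that leaves this position without the measurable value seen with fluoro. Compound 4 gives > 50000 nM, which is a limit of the assay and not a number. The steps from compound 3 to compound 4 and from compound 1 to compound 4 cannot be read, so neither methoxy against trifluoromethyl on the aniline nor methoxy against hydrogen on the phenyl of the core can be ranked, because the series now piles up at one ceiling: the limit of > 50000 nM in this assay, at which 3 of the 4 values shown sit.

Among the compounds shown, fluoro is the only group on the aniline that comes with a measured number, and one compound cannot tell whether that is a lone case or part of a trend; a chloro, a hydroxyl or an amine on the same carbon would help to settle this. Also open, from the compounds shown here alone, is whether the fluoro aniline keeps its value when the methoxy on the phenyl of the core is replaced by hydrogen.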